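Notes on compound 4: 4-fluorophenyl for naphthalen-2-yl

The source may report more compounds than this note shows. Statements on the series, on what has been measured and on what is new or still open speak of the compounds shown alone.

Compound 3 `CCOc1nc(-c2cc3ccccc3o2)cc(-c2ccc3ccccc3c2)c1C#N` gives 423000 nM in a functional assay on aorta (strain Wistar) for inhibition, with Thoracic aorta (Rattus norvegicus) as the target; on this read-out higher numbers stand for weaker inhibition and lower numbers for stronger inhibition. Compound 2 `COc1nc(-c2cc3ccccc3o2)cc(-c2ccc3ccccc3c2)c1C#N` gives 320000 nM, and compound 1 `COc1nc(-c2cc3ccccc3o2)cc(-c2ccccc2)c1C#N` gives 232000 nM; all three numbers lie within the scatter of one another, so compound 3 stands nowhere apart from the rest. Compound 4 `CCOc1nc(-c2cc3ccccc3o2)cc(-c2ccc(F)cc2)c1C#N` differs from compound 3 by 4-fluorophenyl in place of naphthalen-2-yl on an aromatic carbon. Within the data shown here, the only measured step, a 1.3-fold higher number from compound 2 to compound 3 (0.12 log units; within the scatter), concerns the ethoxy group and does not bear on this change. Compound 1 and compound 2 differ in that naphthalen-2-yl replaces phenyl, and their two values show no gap beyond the scatter. From the compounds shown here alone, the 4-fluorophenyl group itself is untested. Compound 4 is therefore expected to show a 1.4-fold lower number from compound 3 to compound 4 (0.15 log units; within the scatter), no step beyond the scatter. The estimate for compound 4 is 300000 nM, within 120000 nM to 750000 nM.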

Compound 4, half-maximal inhibitory concentration: 396000 nM
Compound 4: middle estimate off by 1.3-fold (0.12 log units), on the low side; low and high end bracket the measured number.
By their numbers in this assay, from the lowest: compounds 1, 2, 4 and 3 (each within the scatter of the next).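

At the aromatic carbon opposite the ring nitrogen, 4-fluorophenyl replaces naphthalen-2-yl, one six-membered aromatic ring leaves, and in this assay the result is a 1.1-fold lower number from compound 3 to compound 4 (0.03 log units; within the scatter) with the ethoxy group held constant. This position therefore accepts the smaller fluorinated ring with no change beyond the scatter. Nothing measured accounts for this flat outcome. Still open, from the compounds shown here alone, is whether an amine or a carboxylic acid on this ring, or a longer chain in place of ethoxy, would shift the number beyond the scatter.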